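Pyridin-4-yl for 3-hydroxyphenyl on a carbonyl carbon

The compounds below may be only part of what the source reports. "The series", "measured", "known", "first", "only" and "open" are said of these compounds alone.

Compounds measured so far in a functional assay on MDA-MB-231 cells (Homo sapiens) for antiproliferative activity, with a stated time of 4 days (on this read-out lower numbers stand for stronger inhibition and higher numbers for weaker inhibition), are these.
Compound 1 (`CCCCc1ccc2[nH]c(-c3ccc(OC)cc3)c(/C=N/O)c2c1`) gives 40 nM
Compound 2 (`CCCCc1ccc2[nH]c(-c3ccc(OC)cc3)c(/C=N/NC(=O)c3ccccc3)c2c1`) gives 32 nM
Compound 3 (`CCCCc1ccc2[nH]c(-c3ccc(OC)cc3)c(/C=N/NC(=O)c3cccc(O)c3)c2c1`) gives 30 nM

Compound 3 stands within the scatter of both other compounds. Compound 4 (`CCCCc1ccc2[nH]c(-c3ccc(OC)cc3)c(/C=N/NC(=O)c3ccncc3)c2c1`) carries pyridin-4-yl in place of 3-hydroxyphenyl on a carbonyl carbon. Going by the values given here, three measured steps bear on this change: a 1.1-fold lower number from compound 2 to compound 3 (0.03 log units; within the scatter) on adding hydroxy to the aromatic ring, a 1.3-fold lower number from compound 1 to compound 2 (0.10 log units; within the scatter) and a 1.3-fold lower number from compound 1 to compound 3 (0.12 log units; within the scatter) on replacing hydroxy on a double-bonded nitrogen. Among the compounds with values here, all lie within the scatter, though no measured compound carries pyridin-4-yl. The expected step is a 1.3-fold higher number from compound 3 to compound 4 (0.10 log units; within the scatter) and no direction beyond the scatter is anticipated. Compound 4 is estimated at 38 nM with an expected range from 15 nM to 100 nM in this assay once measured.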

Compound 4, half-maximal inhibitory concentration: 29 nM
Beside the measured number, compound 4's estimate is 1.3-fold (0.12 log units) above it; the range from low to high includes it.
By their numbers in this assay, from the lowest: compounds 4, 3, 2 and 1 (each within the scatter of the next).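

In this assay, pyridin-4-yl on the carbonyl carbon gives a 1.0-fold lower number from compound 3 to compound 4 (0.01 log units; within the scatter) and, against phenyl, a 1.1-fold lower number from compound 2 to compound 4 (0.04 log units; within the scatter), so a ring with a hetero atom and no hydrogen-bond donor leaves the number within the scatter at this position. Replacing hydroxy on the double-bonded nitrogen with ((pyridin-4-yl)carbonyl)amino gives a 1.4-fold lower number from compound 1 to compound 4 (0.14 log units; within the scatter), which keeps all four compounds within the scatter of one another. Nothing at hand offers a reason for this flat picture. From the compounds shown here alone, whether an amine such as piperidin-4-yl or a carboxylic acid on this carbonyl carbon would move the number beyond the scatter stays open.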